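The source may report more compounds than this note shows. Statements on the series, on what has been measured and on what is new or still open speak of the compounds shown alone.

In a functional assay (aorta) with Rattus norvegicus as the target (on this read-out lower numbers stand for an effect already at smaller amounts and higher numbers for an effect only at larger amounts of compound), compound 2 `COc1ccc(-c2nc(/N=C(\N)N3CCOCC3)sc2-c2ccc(OC)cc2)cc1` gives 66 uM, the highest of the two plain numbers shown. Compound 1 `COc1ccc(-c2nc(/N=C(\N)NC3CCCCC3)sc2-c2ccc(OC)cc2)cc1` gives in this assay only a limit, > 100 uM. Compound 3 `COc1ccc(-c2nc(C(=O)N(C)C)sc2-c2ccc(OC)cc2)cc1` gives 3 uM in this assay. The move to compound 4 `CCOC(=O)/C(C#N)=C/c1nc(-c2ccc(OC)cc2)c(-c2ccc(OC)cc2)s1` is a group of 9 heavy atoms (6 carbon, 1 nitrogen, 2 oxygen; no ring) in place of a group of 9 heavy atoms (5 carbon, 3 nitrogen, 1 oxygen; one six-membered non-aromatic ring with 2 hetero atoms), on an aromatic carbon. For the measured compounds named here, two measured steps bear on this change: a 22-fold lower number from compound 2 to compound 3 (1.34 log units; beyond the scatter), and an at least 1.5-fold lower number from compound 1 to compound 2 (0.18 log units; that floor lies within the scatter). Going by the values given here, the one exchange that replaced the ring-bearing group on that aromatic carbon with a group without a ring brought a large drop in the number, so a step toward a lower number is expected here as well, though the entering group differs from that of compound 3; the expected step is a 4.4-fold lower number from compound 2 to compound 4 (0.64 log units; beyond the scatter). Compound 4 is thus estimated at 15 uM, within 3 uM to 70 uM.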

Compound 4, concentration for half-maximal effect: > 100 uM
Compound 4 gave a limit, no number; the forecaster's own chance of this, stated with the estimate: 15%; at least 6.6-fold (0.82 log units) between middle value and limit.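

Compound 3 had suggested that a group without a ring on this aromatic carbon lowers the number in this assay, but the ring-free 2-cyano-2-(ethoxycarbonyl)ethenyl group gives no such drop: an at least 1.5-fold higher number from compound 2 to compound 4 (0.18 log units; that floor lies within the scatter). What enters therefore counts, not just the loss of the ring, as 2-cyano-2-(ethoxycarbonyl)ethenyl in place of dimethylcarbamoyl gives an at least 33-fold higher number from compound 3 to compound 4 (1.52 log units; beyond the scatter). Compound 4 gives only a limit, and it is a shared one: the limit of > 100 uM in this assay, at which 2 of the 4 values shown sit.

The step between compound 1 and compound 4 cannot be read, as both are limits. On these data alone, whether an amine, a carboxylic acid or a longer chain on this aromatic carbon would give a low number remains open.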